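This account rests on a few compounds, and the source may have more. Where it says the series, first, only, none or still open, it means among the compounds named here.

Measured compounds in a functional assay on XF498 cells (Homo sapiens) for antiproliferative activity, read by MTT assay, with a stated time of 96 h; on this read-out lower numbers stand for stronger inhibition and higher numbers for weaker inhibition:
compound 1 `CN(C)c1ccc(N2C(=O)NC3(CSC4=C3C(=O)c3ncccc3C4=O)C2=O)cc1`: 800 nM
compound 2 `O=C1NNC(=O)C2(CSC3=C2C(=O)c2ncccc2C3=O)N1`: 5000 nM
compound 3 `O=C1C2=C(C(=O)c3ncccc31)C1(CS2)NC(=O)N(c2ccc(Cl)cc2)C1=O`: 590 nM

Compound 3 carries the lowest of these three numbers, but its gap to compound 1 lies within the scatter, so the two cannot be told apart; only compound 2 stands clearly apart, beyond the scatter. Compound 4 `CCc1ccc(N2C(=O)NC3(CSC4=C3C(=O)c3ncccc3C4=O)C2=O)cc1` is not yet measured; it differs from compound 3 by ethyl in place of chloro on an aromatic carbon. Among the measured compounds shown here, one measured step bears on this change: a 1.4-fold lower number from compound 1 to compound 3 (0.13 log units; within the scatter), a swap of the group on the same aromatic carbon that barely moved the number. Nothing here points to a large effect of another swap at that carbon, so the step of a 1.1-fold higher number from compound 3 to compound 4 (0.04 log units; within the scatter) is expected to stay within the scatter. Compound 4 is therefore estimated at 650 nM, in a range from 300 nM to 1500 nM.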

Compound 4, half-maximal inhibitory concentration: 1200 nM
Beside the measured number, compound 4's estimate is 1.8-fold (0.27 log units) below it; the range from low to high includes it.
By their numbers in this assay, from the lowest: compounds 3, 1 and 4 (each within the scatter of the next, the first and the last beyond it); then compound 2.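

In this assay, among the compounds shown here, ethyl in place of chloro gives a 2.0-fold higher number from compound 3 to compound 4 (0.31 log units; beyond the scatter), the first step at this aromatic carbon to pass beyond the scatter, though only modestly. Ethyl and dimethylamino still cannot be told apart, with a 1.5-fold higher number from compound 1 to compound 4 (0.18 log units; within the scatter). So this carbon responds to a change of group, but only slightly across these three groups, and nothing available explains the gap between chloro and ethyl.

As far as these compounds go, whether a longer chain such as butyl, or a carboxylic acid, at this carbon would shift the number further remains open.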